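The source may hold more compounds than are shown below. What is called first, only, known or untested is meant among the compounds shown, and "the series" means these compounds.

- compound 1 `Clc1cccc(COC(CCn2ccnc2)c2cccs2)c1` with 46000 nM
- compound 2 `Clc1cccc(COC(CCn2ccnc2)c2ccco2)c1` with 60200 nM
- compound 3 `Clc1cccc(COC(CCn2cncn2)c2cccs2)c1` not yet measured

In an ADME assay on J774.A1 cells (Mus musculus) for cytotoxicity, read by MTT assay, with a stated time of 72 h (a lower number here means that less compound is tolerated, a higher number that more compound is tolerated), compound 1 gives 46000 nM and lies within the scatter of compound 2. Compound 3 carries 1H-1,2,4-triazol-1-yl in place of 1H-imidazol-1-yl on a saturated chain carbon, three bonds along the chain from an aromatic carbon and an oxygen on a saturated carbon on a saturated chain carbon, three bonds along the chain from an aromatic carbon and an oxygen on a saturated carbon. For the measured compounds named here, no measured step covers this change. Going by the values given here, the one measured step of a 1.3-fold higher number from compound 1 to compound 2 (0.12 log units; within the scatter) swaps thiophen-2-yl for furan-2-yl elsewhere and bears only loosely on it, so no shift beyond the scatter is expected in this assay for this change. The expected step is a 1.2-fold higher number from compound 1 to compound 3 (0.08 log units; within the scatter) and stays within the scatter. For compound 3 the estimated value is 55000 nM with an expected range from 28000 nM to 100000 nM as its ends.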

Compound 3, half-maximal cytotoxic concentration: 15600 nM
Compound 3: the middle estimate sits 3.5-fold (0.55 log units) above what was measured; measured number outside the range, below it.
By their numbers in this assay, from the lowest: compound 3; then compounds 1 and 2 (each within the scatter of the next).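

Unlike the exchange of thiophen-2-yl for furan-2-yl, the exchange of 1H-imidazol-1-yl for 1H-1,2,4-triazol-1-yl moves the result beyond the scatter in this assay, with a 2.9-fold lower number from compound 1 to compound 3 (0.47 log units; beyond the scatter). This position therefore affects how much compound is tolerated, and the triazole is the less tolerated of the two groups on the thiophen-2-yl scaffold. No available data explain this shift.

Going by these compounds, it remains open whether the same exchange has a similar effect alongside furan-2-yl. On these data alone, the effect of an amine or a carboxylic acid at this position also remains open.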